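This account rests on a few compounds, and the source may have more. Where it says the series, first, only, none or still open, it means among the compounds named here.

Two chalcone-bearing compounds built on a shared core have been measured in a functional assay on A549 cells (Homo sapiens) for antiproliferative activity, read by MTT assay, with a stated time of 24 h; on this read-out higher numbers stand for weaker inhibition and lower numbers for stronger inhibition. Compound 1 `COc1cc(C(=O)/C=C/c2cc(-c3cc(OC)c(OC)c(OC)c3)n3nc(-c4ccccc4)cc3n2)cc(OC)c1OC` carries a trimethoxyphenyl ketone and a second trimethoxyphenyl on the core, and in this assay compound 1 gives 20500 nM. Compound 2 `COc1ccc(-c2cc(/C=C/C(=O)c3ccc(C)cc3)nc3cc(-c4ccccc4)nn23)cc1OC` replaces the ketone aryl with a methylphenyl and bears a 3,4-dimethoxyphenyl on the core; in this assay compound 2 gives 17200 nM. Within the data shown here, of the two numbers in hand, the one for compound 2 is the smaller, yet the gap to compound 1 is within the scatter, so the two compounds cannot be told apart on these data.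

Compound 3 `COc1cc(-c2cc(/C=C/C(=O)c3ccc(C)cc3)nc3cc(-c4ccccc4)nn23)cc(OC)c1OC` is the next member, not yet measured. It differs from compound 2 in one place: methoxy in place of hydrogen on an aromatic carbon, which, taken one bond further out, reads 3,4-dimethoxyphenyl to 3,4,5-trimethoxyphenyl. Among the measured compounds shown here, no step between measured compounds covers this change, and compound 1, which already holds a 3,4,5-trimethoxyphenyl on the core, sits within the scatter of compound 2. Compound 3 is therefore expected to land close to its parent, with an estimated step of a 1.1-fold lower number from compound 2 to compound 3 (0.06 log units; within the scatter), no larger than the scatter in either direction. The estimate for compound 3 in this assay is 15000 nM, within a range of 5000 nM to 45000 nM.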

Compound 3, half-maximal inhibitory concentration: 19400 nM
For compound 3 the middle estimate is 1.3-fold (0.11 log units) below the measured one, within the range that was stated.
By their numbers in this assay, from the lowest: compounds 2, 3 and 1 (each within the scatter of the next).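

In this assay, among these compounds, adding a methoxy group to the aromatic carbon of the core's 3,4-dimethoxyphenyl, which makes it a 3,4,5-trimethoxyphenyl, gives a 1.1-fold higher number from compound 2 to compound 3 (0.05 log units; within the scatter), the first direct reading of this single change, and it shows that the two compounds cannot be told apart at this position. Among the compounds shown here, the new compound also gives the first single-place reading on the carbonyl carbon, where 4-methylphenyl in place of 3,4,5-trimethoxyphenyl gives a 1.1-fold lower number from compound 1 to compound 3 (0.02 log units; within the scatter), so neither aryl group can be separated from the other on these numbers. Nothing in hand bears on why these results came out as they did.

Going by these compounds, it remains open whether a hydroxy group or an amine in place of the added methoxy would give a step beyond the scatter, since both readings here concern methoxy-bearing or methyl-bearing phenyl groups alone. On these data alone, it is equally open whether a carboxylic acid on the aryl group at the carbonyl carbon, or a longer chain in place of that aryl group, would separate from these compounds in this assay.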